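Working notes: three limits and one expected value

The source may hold more compounds than are shown below. What is called first, only, known or untested is meant among the compounds shown, and "the series" means these compounds.

Measured so far in a functional assay on A549 cells (Homo sapiens) for cytotoxicity, read by MTT assay, with a stated time of 48 h; on this read-out higher numbers stand for weaker inhibition and lower numbers for stronger inhibition:
- compound 1, `C#CCSc1nnc(C)n1N1C(=O)c2ccccc2C1=O`: compound 1 reaches only a limit, > 200000 nM.
- compound 2, `Cc1nnc(SCc2ccccc2Cl)n1N1C(=O)c2ccccc2C1=O`: compound 2 reaches only a limit, > 200000 nM.
- compound 3, `COc1cc(-c2nnc(SCc3ccccc3Cl)n2N2C(=O)c3ccccc3C2=O)cc(OC)c1OC`: compound 3 reaches only a limit, > 200000 nM.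

None of the three gives a number in this assay; all sit at the same limit, (the limit of > 200000 nM in this assay, at which 3 of the 3 values shown sit). The step that the two limits leave unreadable from compound 2 to compound 1 is therefore not readable, and the same holds for a step that the two limits leave unreadable from compound 2 to compound 3.

Compound 2 and compound 3 share a core that differs in one place, (3,4,5-trimethoxyphenyl in place of methyl on an aromatic carbon).

The change from compound 2 to compound 1, (ethynyl in place of 2-chlorophenyl on a saturated chain carbon bound to a sulfur), is repeated from compound 3 to compound 4, (ethynyl in place of 2-chlorophenyl on a saturated chain carbon bound to a sulfur), and the place is the same in both; the unmeasured member is compound 4, `C#CCSc1nnc(-c2cc(OC)c(OC)c(OC)c2)n1N1C(=O)c2ccccc2C1=O`. In the measured pair the size of the step cannot be read, since both ends are limits.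

For compound 4 the expected step that the limit leaves unreadable from compound 3 to compound 4 is set to nothing because the limit of > 200000 nM in this assay, at which 3 of the 3 values shown sit, shows every measured member of the series at the limit, including both ends of the same change, a step that the two limits leave unreadable from compound 2 to compound 1. Compound 4 is thus expected to give about 300000 nM in this assay, which most likely means another limit rather than a number; the range 80000 nM to 1500000 nM is an estimate only. Among the measured compounds shown here, no measured compound contradicts this, but none supports a number either.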

Compound 4, half-maximal inhibitory concentration: > 200000 nM
Compound 4 was reported as a limit (the forecaster's own chance of this, stated with the estimate: 80%); the middle value lies beyond the limit too.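

In this assay compound 4 gives > 200000 nM, a limit and not a number. Compound 3 is a limit as well, so no new step can be read from compound 3 to compound 4. The compounds shown leave open whether the ethynyl or the 3,4,5-trimethoxyphenyl change moves this read-out at all, as no compound gives a number: the limit of > 200000 nM in this assay, at which 4 of the 4 values shown sit.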